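The source may report more compounds than this note shows. Statements on the series, on what has been measured and on what is new or still open speak of the compounds shown alone.

Measured compounds:
compound 1 `Cc1ccc(-c2onc3ccc(/C=C/C(=O)O)cc23)cc1` — 11500 nM
compound 2 `O=C(O)/C=C/c1ccc2noc(-c3ccc(Oc4ccccc4)cc3)c2c1` — 760 nM
compound 3 `O=C(O)/C=C/c1ccc2noc(-c3ccc(-c4ccccc4)cc3)c2c1` — 200 nM

In an assay for inhibition of inositol hexakisphosphate kinase 3 (Homo sapiens), read by colorimetric assay, coupled enzyme assay and malachite green, with a stated time of 120 min, in the presence of a further agent that is not named here (on this read-out higher numbers stand for weaker inhibition and lower numbers for stronger inhibition), compound 1 gives the highest of the three numbers: its nearest neighbour is compound 2 at a 15-fold lower number from compound 1 to compound 2 (1.18 log units; beyond the scatter), and compound 3 lies furthest, at a 58-fold lower number from compound 1 to compound 3 (1.76 log units; beyond the scatter). Between the two lower values the gap is a 3.8-fold lower number from compound 2 to compound 3 (0.58 log units; beyond the scatter).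

Compound 4 `Cc1cccc(-c2onc3ccc(/C=C/C(=O)O)cc23)c1` is the not yet measured partner of compound 1. The change between them is 3-methylphenyl in place of 4-methylphenyl on an aromatic carbon. None of the three measured steps tests this change: each of them swaps the methyl for a larger group, phenoxy or phenyl, and all of them are large. What they do show is that the group on this aromatic carbon governs the number strongly. For the measured compounds named here, a shift of the methyl from the 4-position to the 3-position, with nothing else altered, has no measured counterpart, so the expected step of a 1.3-fold lower number from compound 1 to compound 4 (0.11 log units; within the scatter) is small, most likely within the scatter, with a slight lean toward a lower number. Compound 4 is therefore estimated at 9000 nM, with a range from 3000 nM to 30000 nM.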

Compound 4, half-maximal inhibitory concentration: 3590 nM
Compound 4: middle estimate off by 2.5-fold (0.40 log units), on the high side; low and high end bracket the measured number.
By their numbers in this assay, from the lowest: compound 3; then compound 2; then compound 4; then compound 1.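

With the same atoms and the same heavy-atom count on both sides, moving the methyl alone from 4-methylphenyl to 3-methylphenyl gives a 3.2-fold lower number from compound 1 to compound 4 (0.51 log units; beyond the scatter) in this assay. The earlier compounds shown here changed the size of the group at this aromatic carbon, so this step adds that the placement of a single methyl on the phenyl ring also matters here, although it remains smaller than a 58-fold lower number from compound 1 to compound 3 (1.76 log units; beyond the scatter). Nothing given here accounts for this difference between the two methylphenyl groups.

The compounds shown leave open whether a phenyl or phenoxy group set at the place of the methyl in compound 4 would shift the number in the same direction. They also leave open how a chlorine or a methoxy group in place of that methyl would compare.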